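Acid to methylamide on the chain carbon

The source may hold more compounds than are shown below. What is called first, only, known or untested is meant among the compounds shown, and "the series" means these compounds.

Measured in an assay on tissue (PBMC cells) for agonist activity at Toll-like receptor 8 (Homo sapiens), with a stated time of 24 h; a lower number here means that less compound is needed, a higher number that more compound is needed for the effect:
compound 1, `CCCC[C@H](CCO)Nc1nc(N)nc2cccnc12`: 4300 nM
compound 2, `CCCC[C@H](CN)Nc1nc(N)nc2cccnc12`: 25000 nM
compound 3, `CCCC[C@@H](Nc1nc(N)nc2cccnc12)C(=O)O`: > 50000 nM, which is a limit of the assay, not a number.

Compound 3 thus stands at the top of the numbers shown, at the limit of > 50000 nM in this assay, at which 1 of the 3 values shown sits, and gives no value of its own. Compound 4, `CCCC[C@@H](Nc1nc(N)nc2cccnc12)C(=O)NC`, differs from compound 3 by methylamino in place of hydroxy on a carbonyl carbon. For the measured compounds named here, two measured steps bear on this change, both leading into compound 3: an at least 11-fold higher number from compound 1 to compound 3 (1.06 log units; beyond the scatter), beyond the scatter, and an at least 2.0-fold higher number from compound 2 to compound 3 (0.30 log units; that floor lies within the scatter), whose floor lies within it. In each, putting carboxy on the chain carbon carried the number upward to the limit. Taking the carboxy away again, toward methylcarbamoyl, is therefore expected to move compound 4 back downward in this assay, though the size of that step is uncertain because compound 3 sits at the limit of > 50000 nM in this assay, at which 1 of the 3 values shown sits, and the true starting point is unknown. The expected step is an at least 2.5-fold lower number from compound 3 to compound 4 (0.39 log units; beyond the scatter). Compound 4 is estimated at 20000 nM, with a range from 5000 nM to 60000 nM, and a fair chance that only a limit is returned.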

Compound 4, half-maximal effective concentration: > 50000 nM
Compound 4: no number, only a limit; the forecaster's own chance of this, stated with the estimate: 40%; at least 2.5-fold (0.39 log units) between middle value and limit.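

In this assay compound 4 gives > 50000 nM, which is a limit of the assay and not a number. Methylamino in place of hydroxy on the carbonyl carbon therefore brings no reading into the measurable range, and the step between compound 3 and compound 4 cannot be read, with both compounds now at the same ceiling: the limit of > 50000 nM in this assay, at which 2 of the 4 values shown sit. Against the compounds that do give numbers, the new amide shows an at least 11-fold higher number from compound 1 to compound 4 (1.06 log units; beyond the scatter) and an at least 2.0-fold higher number from compound 2 to compound 4 (0.30 log units; that floor lies within the scatter), so among these four compounds both groups with a carbonyl on this chain carbon stay at the limit, although only the first of these two steps is clear of the scatter.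

As far as these compounds go, how far compound 3 and compound 4 lie beyond the limit stays open, and so does whether the change from carboxy to methylcarbamoyl shifts the response in either direction. Also open, from the compounds shown here alone, is whether hydroxymethyl, carbamoyl or dimethylcarbamoyl on this chain carbon, or a longer chain carrying the hydroxy group of compound 1, would give a number in this assay.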